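This account rests on a few compounds, and the source may have more. Where it says the series, first, only, none or still open, it means among the compounds named here.

Series notes. Compound 1 `Cn1c(CCc2ccccc2)nc2cc(Cl)c(Cl)cc21` in a functional assay on HepG2 cells (Homo sapiens) for cytotoxicity (a higher number here means that more compound is tolerated, a lower number that less compound is tolerated), gives 15300 nM, the lowest of the two numbers at hand. Compound 2 `Cc1ccc(S(=O)(=O)n2c(CN3C(=O)c4ccccc4C3=O)nc3cc(Cl)c(Cl)cc32)cc1` gives 90000 nM in this assay, a gap from compound 1 that lies beyond the scatter. Compound 3 `CCCc1nc2cc(Cl)c(Cl)cc2n1C` differs from compound 1 by methyl in place of phenyl on a saturated chain carbon, two bonds along the chain from an aromatic carbon. Within the data shown here, no measured pair covers this change, so the direction rests on expectation alone: a small rise is expected, estimated at a 1.6-fold higher number from compound 1 to compound 3 (0.21 log units; within the scatter), not clearly beyond the scatter. For compound 3 in this assay the estimate is 25000 nM, with a range from 8000 nM to 80000 nM.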

Compound 3, half-maximal cytotoxic concentration: 24600 nM
Estimate against measurement, compound 3: 1.0-fold (0.01 log units) above; low and high end bracket the measured number.
By their numbers in this assay, from the lowest: compounds 1 and 3 (each within the scatter of the next); then compound 2.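

In this assay, among these compounds, the swap of methyl for phenyl on a saturated chain carbon, two bonds along the chain from an aromatic carbon, gives a 1.6-fold higher number from compound 1 to compound 3 (0.21 log units; within the scatter), the first reading of this change. At this place, the phenyl ring can thus be lost with no shift beyond the scatter. No measured property bears on this result.

From the compounds shown here alone, whether an amine, a carboxylic acid or a longer chain in the same place would also stay within the scatter of compound 1 remains open.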